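Working notes: ethoxy in place of ethylamino

This account rests on a few compounds, and the source may have more. Where it says the series, first, only, none or still open, it means among the compounds named here.

Measured in a functional assay on the whole organism for inhibition, with Mus musculus as the target; on this read-out lower numbers stand for an effect already at smaller amounts and higher numbers for an effect only at larger amounts of compound:
- compound 1 `CN1Cc2c(N)cccc2C(c2ccc(F)cc2)C1`: about 3.6 mg/kg
- compound 2 `CCNC(=O)Nc1cccc2c1CN(C)CC2c1ccccc1`: 80 mg/kg
- compound 3 `CCCCNC(=O)Nc1cccc2c1CN(C)CC2c1ccc(C)cc1`: 40 mg/kg

Compound 2 lies within the scatter of compound 3, and the number for compound 2 is clearly higher than that for compound 1, a gap well beyond the scatter. Going by the values given here, the set is small, and no two measured compounds differ in only one place, so no measured step is available for comparison.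

Compound 4 `CCOC(=O)Nc1cccc2c1CN(C)CC2c1ccccc1` has not yet been measured in this assay. It differs from compound 2 by ethoxy in place of ethylamino on a carbonyl carbon. Among the compounds with values here, no measured pair shows this exchange, so the expectation rests on a loose comparison. Compound 3 also carries an amino group on the carbonyl carbon, with a chain other than ethyl, and gives 40 mg/kg. Compound 1 has no such carbonyl and gives about 3.6 mg/kg. With so little to go on, only a slight shift towards a lower number is expected, and nothing beyond the scatter. The expected step is a 1.6-fold lower number from compound 2 to compound 4 (0.20 log units; within the scatter). The estimate for compound 4 is 50 mg/kg, with an expected range of 15 mg/kg to 130 mg/kg.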

Compound 4, dose for half-maximal effect: 3.2 mg/kg
Beside the measured number, compound 4's estimate is 16-fold (1.19 log units) above it; measured number outside the range, below it.
By their numbers in this assay, from the lowest: compounds 4 and 1 (each within the scatter of the next); then compounds 3 and 2 (each within the scatter of the next).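

Ethoxy in place of ethylamino on a carbonyl carbon gives a 25-fold lower number from compound 2 to compound 4 (1.40 log units; beyond the scatter) in this assay, the first step in the series that can be read at a single place. It shows that the result at this carbonyl carbon depends strongly on what links the ethyl chain to it, even though the two groups have the same count of 3 heavy atoms and neither has a ring or a net charge. What differs is one nitrogen for one oxygen, with ethylamino counted as 1 hydrogen-bond donor and 0 hydrogen-bond acceptors and ethoxy as 0 hydrogen-bond donors and 1 hydrogen-bond acceptor, and nothing available bears on why the step is this large.

The compounds shown leave open whether the lower number belongs to the ethyl ester-type link in particular or holds for other alkoxy groups on the same carbonyl carbon, such as methoxy or a longer chain like butoxy. They also leave open what a dimethylamino group at this place would give, with nitrogen kept but the amide hydrogen gone.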